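The source may hold more compounds than are shown below. What is called first, only, known or untested is meant among the compounds shown, and "the series" means these compounds.

Measured so far in an ADME assay (Rattus norvegicus) for metabolic stability; a higher number here means that the compound lasts longer, a lower number that the compound disappears faster:
compound 1, `O=C(O)[C@@H](CC1CCC1)N1C[C@H](CN2CCC(c3cnc4ccc([N+](=O)[O-])cn34)CC2)[C@@H](c2cccc(F)c2)C1`, gives 0.2 h.
compound 2, `O=C(O)[C@@H](CC1CCC1)N1C[C@H](CN2CCC(CCCc3ccccc3)CC2)[C@@H](c2ccccc2)C1`, gives 3 h.
compound 3, `O=C(O)[C@@H](CC1CCC1)N1C[C@H](CN2CCC(c3cnc4ccc(Cl)cn34)CC2)[C@@H](c2cccc(F)c2)C1`, gives 0.7 h.

Compound 1 stands lowest of these three numbers. The nearest to it is compound 3, with a 3.5-fold higher number from compound 1 to compound 3 (0.54 log units; beyond the scatter), while compound 2 lies furthest away with a still higher number.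

Compound 4, `O=C(O)[C@@H](CC1CCC1)N1C[C@H](CN2CCC(c3cnc4c(Cl)cc(Cl)cn34)CC2)[C@@H](c2cccc(F)c2)C1`, differs from compound 1 in one place: a group of 11 heavy atoms (7 carbon, 2 nitrogen, 2 chlorine; one five-membered aromatic ring with 2 hetero atoms, one six-membered aromatic ring with 1 hetero atom) in place of a group of 12 heavy atoms (7 carbon, 3 nitrogen, 2 oxygen; one five-membered aromatic ring with 2 hetero atoms, one six-membered aromatic ring with 1 hetero atom), on a saturated ring carbon. Among the compounds with values here, the only measured step that bears on this change is a 3.5-fold higher number from compound 1 to compound 3 (0.54 log units; beyond the scatter), where chloro took the place of nitro on an aromatic carbon. Compound 4 also loses the nitro group and gains chlorine, so a rise of about that size, beyond the scatter, is expected in this assay; the expected step is a 5.0-fold higher number from compound 1 to compound 4 (0.70 log units; beyond the scatter). Compound 4 is therefore estimated at 1 h, within a range from 0.4 h to 2.5 h.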

Compound 4, half-life: 0.4 h
Beside the measured number, compound 4's estimate is 2.5-fold (0.40 log units) above it; measured number inside the range.
By their numbers in this assay, from the lowest: compounds 1, 4 and 3 (each within the scatter of the next, the first and the last beyond it); then compound 2.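

Chloro in place of hydrogen on an aromatic carbon gives a 1.8-fold lower number from compound 3 to compound 4 (0.24 log units; within the scatter) in this assay, so this added chlorine does not separate the two compounds. Against the nitro compound, the group with two chlorines gives a 2.0-fold higher number from compound 1 to compound 4 (0.30 log units; within the scatter), so unlike the single chloro of compound 3 it does not clear the usual scatter. No measurement shown here offers an explanation for either step. Still open, going by these compounds, is whether methoxy or a nitrile on that aromatic carbon would take compound 3 beyond the scatter in either direction.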